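Returning to a carbon-only ring on the piperazine nitrogen

The source may hold more compounds than are shown below. What is called first, only, known or untested is meant among the compounds shown, and "the series" means these compounds.

Three compounds share a core in which a piperazine carries an aryl group on one nitrogen. Compound 1 `CN(C)C(=O)c1cccnc1NCCCN1CCN(c2ccccc2)CC1` gives 6.31 nM in a functional assay for antagonist activity at Alpha-1A adrenergic receptor (Oryctolagus cuniculus); on this read-out lower numbers stand for tighter binding and higher numbers for weaker binding. Compound 2 `CN(C)C(=O)c1cccnc1NCCCN1CCN(c2ccccc2O)CC1` gives 5.01 nM in this assay, and the change a 1.3-fold lower number from compound 1 to compound 2 (0.10 log units; within the scatter). Compound 3 `Cc1cnccc1N1CCN(CCCNc2ncccc2C(=O)N(C)C)CC1` gives 200 nM, the highest number of the three: the change a 32-fold higher number from compound 1 to compound 3 (1.50 log units; beyond the scatter), and the change a 40-fold higher number from compound 2 to compound 3 (1.60 log units; beyond the scatter).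

Compound 4 `CC(C)c1ccccc1N1CCN(CCCNc2ncccc2C(=O)N(C)C)CC1` has not been measured. It differs from compound 3 by 2-isopropylphenyl in place of 3-methylpyridin-4-yl on an amine nitrogen in a ring. The measured steps that bear on it are the two leading into compound 3, since both replace a carbon-only aromatic ring with the 3-methylpyridin-4-yl group and both raise the number by a large amount beyond the scatter. Within the data shown here, compound 4 moves the other way, back to a carbon-only ring, though the isopropyl group it carries has no measured counterpart here. The step from compound 3 to compound 4 is therefore expected to be a large decrease in this assay, roughly undoing what was seen from compound 1 to compound 3, with the estimated change being a 17-fold lower number from compound 3 to compound 4 (1.22 log units; beyond the scatter). For compound 4 the estimated value is 12 nM, expected to fall between 3 nM and 50 nM.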

Compound 4, dissociation constant: 0.398 nM
The estimate for compound 4 lay 30-fold (1.48 log units) above the measured number; the whole stated range lies above it.
By their numbers in this assay, from the lowest: compound 4; then compounds 2 and 1 (each within the scatter of the next); then compound 3.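

In this assay, isopropyl in place of hydrogen on the aromatic carbon gives a 16-fold lower number from compound 1 to compound 4 (1.20 log units; beyond the scatter), and isopropyl in place of hydroxy on that same carbon gives a 13-fold lower number from compound 2 to compound 4 (1.10 log units; beyond the scatter), while the earlier change there, hydroxy in place of hydrogen, gave only a 1.3-fold lower number from compound 1 to compound 2 (0.10 log units; within the scatter). This aromatic carbon therefore does respond to substitution, which compound 1 and compound 2 alone had not shown, and the response depends on the group placed there. The change on the amine nitrogen gives a 500-fold lower number from compound 3 to compound 4 (2.70 log units; beyond the scatter), a larger step than either of those leading into compound 3, so a carbon-only ring carrying isopropyl does more than reverse the rise seen with 3-methylpyridin-4-yl.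

Nothing available here explains the size of these steps. From the compounds shown here alone, whether a methoxy, ethyl or tert-butyl group on that aromatic carbon would lower the number as isopropyl does remains open, as does whether isopropyl on a pyridine ring would do the same, since the step from compound 3 to compound 4 changes the ring and adds isopropyl together.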